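Mirror Image of the Isopropyl Side Chain

This account rests on a few compounds, and the source may have more. Where it says the series, first, only, none or still open, it means among the compounds named here.

The compounds share one core, an imidazole dicarboxamide bearing a dichloroanilide, and differ in the amino-acid-derived side chain. Compound 1 `COC(=O)[C@@H](C)NC(=O)c1[nH]cnc1C(=O)Nc1ccc(Cl)c(Cl)c1` carries a methyl, compound 2 `COC(=O)[C@@H](NC(=O)c1[nH]cnc1C(=O)Nc1ccc(Cl)c(Cl)c1)c1ccccc1` a phenyl, and compound 3 `COC(=O)[C@H](NC(=O)c1[nH]cnc1C(=O)Nc1ccc(Cl)c(Cl)c1)C(C)C` an isopropyl at the saturated chain carbon bound to an amide-type nitrogen and a carbonyl carbon. In a functional assay on HL-60 cells (Homo sapiens), with a stated time of 4 days (a lower number here means a stronger inhibitor, a higher number a weaker inhibitor), compound 1 gives only a limit, > 62500 nM, so its value is not a number (the limit of > 62500 nM in this assay, at which 1 of the 3 values shown sits). Compound 2 gives 6800 nM and compound 3 gives 4900 nM, two numbers within the scatter of each other. Among the measured compounds shown here, the one clear step is an at least 12-fold lower number from compound 1 to compound 3 (1.10 log units; beyond the scatter), which concerns the size of the side chain.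

Compound 4 `COC(=O)[C@@H](NC(=O)c1[nH]cnc1C(=O)Nc1ccc(Cl)c(Cl)c1)C(C)C` differs from compound 3 only in configuration: the two compounds have the same atoms and bonds and differ only in configuration as drawn: 1 of 1 stereo elements differ; a stereocentre at a saturated chain carbon is drawn R in compound 3 and S in compound 4. For the measured compounds named here, no measured step involves a change of configuration, so none bears on this change, and the step from compound 1 to compound 3 offers no guidance on a mirror-image side chain. The expectation is therefore uncertain; compound 4 is estimated at 12000 nM, within 3000 nM to 62500 nM, an expected step of a 2.4-fold higher number from compound 3 to compound 4 (0.39 log units; beyond the scatter).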

Compound 4, half-maximal inhibitory concentration: > 62500 nM
Compound 4 was reported as a limit (the forecaster's own chance of this, stated with the estimate: 25%); middle value at least 5.2-fold (0.71 log units) from the limit.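

In this assay, among the compounds shown here, the change is an at least 12-fold higher number from compound 3 to compound 4 (1.10 log units; beyond the scatter) and, unlike the earlier pairs, this one isolates configuration at the saturated chain carbon, as the only difference is this: the fact that compounds 3 and 4 differ only in the configuration as drawn. The value of compound 4 is a limit of the assay and not a number: the limit of > 62500 nM in this assay, at which 2 of the 4 values shown sit. Set against the phenyl side chain, the picture is an at least 9.1-fold higher number from compound 2 to compound 4 (0.96 log units; beyond the scatter) and so an isopropyl side chain of the right size does not by itself keep the number low, since the configuration drawn in compound 3 is needed as well.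

The step between compounds 1 and 4 cannot be read, as both values are limits. Open, on these data alone, are the mirror images of compounds 1 and 2, and whether a carboxylic acid in place of the methyl ester or a longer chain at this carbon shows the same dependence on configuration.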